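Swapping a Ring Nitrogen Out of a Tetrazole Series

The compounds below may be only part of what the source reports. "The series", "measured", "known", "first", "only" and "open" are said of these compounds alone.

Of the compounds shown here, three have been tested in a toxicity assay on HepG2 cells (Homo sapiens) for cytotoxicity, read by CellTiter-Glo, with a stated time of 72 h; a higher number here means that more compound is tolerated, a lower number that less compound is tolerated. Compound 1 `Cc1ccccc1-n1nnnc1C(c1cccnc1)N(Cc1cccc(C(F)(F)F)c1)C1CC1` gives 15000 nM in this assay. Compound 2 `Cc1ccccc1-n1nnnc1C(c1cncnc1)N(Cc1cccc(C(F)(F)F)c1)C1CC1` gives 33000 nM in this assay. Compound 3 `CCCN(C(c1cncnc1)c1nnnn1-c1ccccc1C)C1(c2cccc(C(F)(F)F)c2)CC1` gives 13000 nM in this assay, the lowest of the three numbers, though its gap to compound 1 lies within the scatter and only its gap to compound 2 lies beyond it.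

Compounds 1 and 2 differ in one place: pyridin-3-yl in place of pyrimidin-5-yl on a saturated chain carbon bound to an amine nitrogen and an aromatic carbon This change made the step of a 2.2-fold lower number from compound 2 to compound 1 (0.34 log units; beyond the scatter), a modest drop in the tolerated concentration.

Compound 4 `CCCN(C(c1cccnc1)c1nnnn1-c1ccccc1C)C1(c2cccc(C(F)(F)F)c2)CC1` is not yet measured. It is related to compound 3 by the same change: pyridin-3-yl in place of pyrimidin-5-yl on a saturated chain carbon bound to an amine nitrogen and an aromatic carbon The cores of compound 3 and compound 2 differ in more than one place, and the difference between the two cores is not broken down here; still, the place of the change is described in the same words in both pairs.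

The expectation for compound 4 in this assay rests on the step seen from compound 2 to compound 1, because a 2.2-fold lower number from compound 2 to compound 1 (0.34 log units; beyond the scatter) shows the direction this change took once before on a related core. A step of about a 2.0-fold lower number from compound 3 to compound 4 (0.30 log units; within the scatter) is therefore expected from compound 3 to compound 4. Compound 4 is estimated at 6500 nM, most likely between 3000 nM and 14000 nM.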

Compound 4, half-maximal cytotoxic concentration: 10000 nM
Beside the measured number, compound 4's estimate is 1.5-fold (0.19 log units) below it, and the stated range covers the measured number.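

On the core of compound 3, putting pyridin-3-yl in place of pyrimidin-5-yl gives a 1.3-fold lower number from compound 3 to compound 4 (0.11 log units; within the scatter) in this assay, so this pair cannot be told apart in this assay, even though the same swap gave a step beyond the scatter on the other core. Set side by side, the two steps are no further apart than two such steps can be by chance alone: the same change on two cores in this assay, a 2.2-fold lower number (0.34 log units; beyond the scatter) from compound 2 to compound 1 and a 1.3-fold lower number (0.11 log units; within the scatter) from compound 3 to compound 4, 1.7-fold (0.23 log units) apart, within the scatter of two such steps This fits the change carrying over from one core to the other with a similar effect, but it does not show that the effect is the same size on both cores, and two pairs are too few to make a rule for other cores or to say why the number moves.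

From the compounds shown here alone, all four compounds carry either pyridin-3-yl or pyrimidin-5-yl at this place, so it remains open how a plain phenyl ring, with no ring nitrogen at all, would compare there. Going by these compounds, it is also open whether the swap would give a similar step on a core carrying a further group such as an amine or a carboxylic acid.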